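Compound 3 to its diethylcarbamoyl counterpart, compound 4

The compounds below may be only part of what the source reports. "The series", "measured", "known", "first", "only" and "open" are said of these compounds alone.

compound 1 `CC(=O)OC/C1=C/C[C@](C)(CCC=C(C)C)/C=C/[C@@H](OC(=O)C=C(C)C)[C@](C)(O)/C=C/C1=O` gives 2950 nM
compound 2 `CCN(CC)C/C1=C/C[C@](C)(CCC=C(C)C)/C=C/[C@@H](OC(=O)C=C(C)C)[C@](C)(O)/C=C/C1=O` gives 270 nM
compound 3 `CO/N=C/C1=C/C[C@](C)(CCC=C(C)C)/C=C/[C@@H](OC(=O)C=C(C)C)[C@](C)(O)/C=C/C1=O` gives 2630 nM

These values come from a functional assay on SW480 cells (Homo sapiens) for antiproliferative activity, read by MTT assay, with a stated time of 48 h (on this read-out higher numbers stand for weaker inhibition and lower numbers for stronger inhibition), and place compound 3 level with compound 1 (a 1.1-fold lower number from compound 1 to compound 3 (0.05 log units; within the scatter)) and well apart from compound 2 (a 9.7-fold higher number from compound 2 to compound 3 (0.99 log units; beyond the scatter)). Compound 4 `CCN(CC)C(=O)/C1=C/C[C@](C)(CCC=C(C)C)/C=C/[C@@H](OC(=O)C=C(C)C)[C@](C)(O)/C=C/C1=O` exchanges one group of compound 3 (a group of 7 heavy atoms (5 carbon, 1 nitrogen, 1 oxygen; no ring) in place of a group of 4 heavy atoms (2 carbon, 1 nitrogen, 1 oxygen; no ring), on a double-bonded ring carbon). The nearest guide is compound 2, which carries diethylamino on a saturated chain carbon (an 11-fold lower number from compound 1 to compound 2 (1.04 log units; beyond the scatter)). Compound 4 instead bears diethylcarbamoyl on a double-bonded ring carbon, so only part of that step is expected to carry over. Only a small move toward a lower number is therefore expected (a 1.9-fold lower number from compound 3 to compound 4 (0.27 log units; within the scatter)). Compound 4 is estimated at 1400 nM (expected range 450 nM to 4000 nM).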

Compound 4, half-maximal inhibitory concentration: 11700 nM
Compound 4: middle estimate off by 8.4-fold (0.92 log units), on the low side; the whole stated range lies below it.
By their numbers in this assay, from the lowest: compound 2; then compounds 3 and 1 (each within the scatter of the next); then compound 4.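

Placing a carbonyl on the carbon that links the diethylamino nitrogen to the double-bonded ring carbon removes the advantage of compound 2 (a 43-fold higher number from compound 2 to compound 4 (1.64 log units; beyond the scatter)), so the diethylamino group alone does not secure a low number. Diethylcarbamoyl also falls behind the other two groups at this position (a 4.4-fold higher number from compound 3 to compound 4 (0.65 log units; beyond the scatter); a 4.0-fold higher number from compound 1 to compound 4 (0.60 log units; beyond the scatter)), leaving compound 4 with the highest number of the four. Nothing available here explains these differences.

The compounds shown leave open how a (dimethylamino)methyl, pyrrolidin-1-ylmethyl or aminomethyl group would compare with the (diethylamino)methyl group of compound 2.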